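Carbamoyl in place of ethyl: compound 2 to compound 4

The source may report more compounds than this note shows. Statements on the series, on what has been measured and on what is new or still open speak of the compounds shown alone.

Going by the values given here, in an ADME assay on HepG2 cells (Homo sapiens) for cytotoxicity, with a stated time of 72 h (a higher number here means that more compound is needed for the effect, a lower number that less compound is needed), compound 2 `CCc1ccc(NC(=O)Nc2cc(C)nc3ccccc23)cc1` gives 17000 nM, the only exact number among the three measured compounds. Compound 1 `Cc1cc(NC(=O)Nc2ccccc2OC(F)(F)F)c2ccccc2n1` gives > 25000 nM, which is a limit of the assay. Compound 3 `Cc1cc(NC(=O)Nc2cccc(C(N)=O)c2)c2ccccc2n1`, which also carries a carbamoyl, gives > 25000 nM, again a limit. Compound 4 `Cc1cc(NC(=O)Nc2ccc(C(N)=O)cc2)c2ccccc2n1` has carbamoyl in place of the ethyl of compound 2, on an aromatic carbon, para to a large group (carbamoyl in place of ethyl on an aromatic carbon). Among the compounds with values here, no measured pair shows this change, so compound 3 at > 25000 nM is the only guide, and it points towards more compound being needed. The expected step of a 1.8-fold higher number from compound 2 to compound 4 (0.25 log units; within the scatter) is small, about the size of the scatter. Compound 4 is estimated at 30000 nM, with an expected range of 18000 nM to 60000 nM.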

Compound 4, half-maximal effective concentration: > 25000 nM
Compound 4 gave a limit, no number; the forecaster's own chance of this, stated with the estimate: 80%; the middle value does not contradict the limit.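

In this assay, carbamoyl in place of ethyl on an aromatic carbon, para to a large group, gives an at least 1.4-fold higher number from compound 2 to compound 4 (0.16 log units; that floor lies within the scatter). Going by these compounds alone, this is the first pair among the compounds that differs in one place, so the change can now be read directly rather than inferred from compound 3. The reading is only a floor, and the true size of the step stays hidden: the limit of > 25000 nM in this assay, at which 3 of the 4 values shown sit.

Going by these compounds, whether the real step lies beyond the scatter remains open. So does what an amine, a carboxylic acid or a longer chain at this position would give in this assay.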